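Removing the nitro group from compound 3

The source may hold more compounds than are shown below. What is called first, only, known or untested is meant among the compounds shown, and "the series" means these compounds.

Compound 3 `N#CC1CN1C(=O)Nc1ccc([N+](=O)[O-])cc1` gives 3700 nM in a functional assay on WiDr cells (Homo sapiens) for inhibition (on this read-out lower numbers stand for stronger inhibition and higher numbers for weaker inhibition), the lowest of the three numbers in hand. Compound 2 `CCOC(=O)c1ccc(NC(=O)N2CC2C#N)cc1` gives 4200 nM and compound 1 `N#CC1CN1C(=O)Nc1ccc(F)cc1` gives 9000 nM; the step of a 1.1-fold lower number from compound 2 to compound 3 (0.06 log units; within the scatter) lies within the scatter, whereas a 2.4-fold lower number from compound 1 to compound 3 (0.39 log units; beyond the scatter) lies beyond it. Compound 4 `N#CC1CN1C(=O)Nc1ccccc1` carries no substituent at this position: hydrogen in place of nitro on an aromatic carbon. Going by the values given here, no measured step exchanges a substituent for hydrogen, so only a 2.1-fold lower number from compound 1 to compound 2 (0.33 log units; beyond the scatter) and a 2.4-fold lower number from compound 1 to compound 3 (0.39 log units; beyond the scatter) bear on the change, both modest, showing that the group para to the group of 8 heavy atoms shifts the number only moderately. Compound 4 is therefore expected to give a higher number than compound 3, a step of a 2.4-fold higher number from compound 3 to compound 4 (0.39 log units; beyond the scatter) roughly undoing that gain. Compound 4 is estimated at 9000 nM, within 3500 nM to 23000 nM.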

Compound 4, half-maximal inhibitory concentration: 12000 nM
Beside the measured number, compound 4's estimate is 1.3-fold (0.12 log units) below it; the measured number falls inside the stated range.
By their numbers in this assay, from the lowest: compounds 3 and 2 (each within the scatter of the next); then compounds 1 and 4 (each within the scatter of the next).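

In this assay, going by these compounds alone, hydrogen gives the first direct reading of the bare position: a 3.2-fold higher number from compound 3 to compound 4 (0.51 log units; beyond the scatter) and a 2.9-fold higher number from compound 2 to compound 4 (0.46 log units; beyond the scatter) show that nitro and ethoxycarbonyl each hold a modest advantage over no substituent. Fluoro shows no such advantage, with a 1.3-fold higher number from compound 1 to compound 4 (0.12 log units; within the scatter) staying within the scatter. No measurement at hand explains these steps. Going by these compounds, whether an amine or a carboxylic acid at this position would give a number lower than compound 3 remains open. So does the effect of a longer chain in place of ethoxycarbonyl.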